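Replacing the nitrile of compound 3 with a dimethylamino group

The compounds below may be only part of what the source reports. "The series", "measured", "known", "first", "only" and "open" are said of these compounds alone.

Compound 1, `CCCn1c(=O)n(CC(=O)O)c(=O)c2[nH]cnc21`, in an assay on Cerebral cortex for binding affinity to adenosine receptor A1 (Cavia porcellus), read by radioligand binding (on this read-out lower numbers stand for stronger inhibition and higher numbers for weaker inhibition), gives > 200000 nM, which is a limit of the assay and not a number.
Compound 2, `CCCn1c(=O)n(CCC(=O)O)c(=O)c2[nH]cnc21`, in this assay gives > 200000 nM, again a limit.
Compound 3, `CCCn1c(=O)n(CCC#N)c(=O)c2[nH]cnc21`, in this assay gives 15900 nM.

Among the compounds with values here, compound 3 therefore holds the only number among the three; the other two sit at the limit of > 200000 nM in this assay, at which 2 of the 3 values shown sit. The step of an at least 12-fold lower number from compound 1 to compound 3 (1.09 log units; beyond the scatter) and the step of an at least 12-fold lower number from compound 2 to compound 3 (1.09 log units; beyond the scatter) both describe the move from a carboxy group to a nitrile, and both are large; the step that the two limits leave unreadable from compound 1 to compound 2 cannot be read, since both ends are limits.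

Compound 4, `CCCn1c(=O)n(CCN(C)C)c(=O)c2[nH]cnc21`, differs from compound 3 by dimethylamino in place of cyano on a saturated chain carbon, two bonds along the chain from an aromatic nitrogen. Within the data shown here, none of the measured steps involves a dimethylamino group; what they show is only that the carboxy compounds sit at the limit while the nitrile compound gives a number. Among the measured compounds shown here, with no step that speaks directly to this change, compound 4 is expected to stay near compound 3, with a step of a 1.6-fold higher number from compound 3 to compound 4 (0.20 log units; within the scatter) that is not expected to go clearly beyond the scatter in either direction. Compound 4 is thus estimated at 25000 nM, within 5000 nM to 150000 nM.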

Compound 4, inhibition constant: 4300 nM
Estimate against measurement, compound 4: 5.8-fold (0.76 log units) above, and the stated range ends above it.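

At this position, on a saturated chain carbon, two bonds along the chain from an aromatic nitrogen, the nitrile of compound 3 does not mark the lowest number in this assay: the change to dimethylamino brings a 3.7-fold lower number from compound 3 to compound 4 (0.57 log units; beyond the scatter). Set against the carboxy compounds, the gap is far wider, with an at least 46-fold lower number from compound 2 to compound 4 (1.66 log units; beyond the scatter) and an at least 46-fold lower number from compound 1 to compound 4 (1.66 log units; beyond the scatter), and both of these steps start from a limit of the assay and not from a number. Two quite different groups, cyano and dimethylamino, therefore both give a readable value here, while the carboxy compounds stay at a limit: the limit of > 200000 nM in this assay, at which 2 of the 4 values shown sit.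

The compounds shown leave open whether the lower number of compound 4 depends on the two methyl groups, as a primary amine or a diethylamino group at the same place would test. They also leave open how dimethylamino would read on a shorter or a longer chain, and the step between the two carboxy chains cannot be read, as both of its ends are limits.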